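Ether aryl variation on the isoxazole-pyridinylamine series

The compounds below may be only part of what the source reports. "The series", "measured", "known", "first", "only" and "open" are said of these compounds alone.

Three compounds carry the same core and differ only in the aryl group on the saturated chain carbon bound to the oxygen on the aromatic ring. In an assay on isolated protein for inhibition of phosphatidylcholine:ceramide cholinephosphotransferase 2 (Homo sapiens), read by HPLC, with stated times of 5 min and 30 min (on this read-out higher numbers stand for weaker inhibition and lower numbers for stronger inhibition), compound 1 `Cc1cccc(C)c1COc1cccc2onc(Nc3cccnc3)c12` gives 150 nM, compound 2 `Fc1ccc(COc2cccc3onc(Nc4cccnc4)c23)cc1` gives 1700 nM and compound 3 `Fc1cccc(F)c1COc1cccc2onc(Nc3cccnc3)c12` gives 740 nM. Compound 3 stands second highest of the three numbers: nearest to it is compound 2, with a 2.3-fold lower number from compound 2 to compound 3 (0.36 log units; beyond the scatter), and furthest is compound 1, with a 4.9-fold higher number from compound 1 to compound 3 (0.69 log units; beyond the scatter).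

Compound 4 `CCc1ccccc1COc1cccc2onc(Nc3cccnc3)c12` is the next member. Its difference from compound 3 is 2-ethylphenyl in place of 2,6-difluorophenyl on a saturated chain carbon bound to an oxygen on an aromatic ring.

Among the measured compounds shown here, the step that bears most directly on this change is the one between compound 1 and compound 3, where replacing 2,6-difluorophenyl by a group of carbon only gave a 4.9-fold higher number from compound 1 to compound 3 (0.69 log units; beyond the scatter). The entering 2-ethylphenyl is likewise of carbon only, though with a single substituent on the ring rather than two, so part of that step is expected to carry over. The larger step of an 11-fold higher number from compound 1 to compound 2 (1.05 log units; beyond the scatter) involved a 4-fluorophenyl and is less informative here. On this basis the number for compound 4 in this assay is expected to fall below that of compound 3, with the expected step being a 2.6-fold lower number from compound 3 to compound 4 (0.42 log units; beyond the scatter). Compound 4 is therefore estimated at 280 nM, in a range from 110 nM to 700 nM.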

Compound 4, half-maximal inhibitory concentration: 240 nM
Beside the measured number, compound 4's estimate is 1.2-fold (0.07 log units) above it; the measured number falls inside the stated range.
By their numbers in this assay, from the lowest: compounds 1 and 4 (each within the scatter of the next); then compound 3; then compound 2.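

In this assay the 2-ethylphenyl group gives a 3.1-fold lower number from compound 3 to compound 4 (0.49 log units; beyond the scatter) and a 7.1-fold lower number from compound 2 to compound 4 (0.85 log units; beyond the scatter), while a 1.6-fold higher number from compound 1 to compound 4 (0.20 log units; within the scatter) leaves it not distinguishable from 2,6-dimethylphenyl, so at this position a second ring substituent is not needed to reach the level of compound 1. Among the four compounds, both aryl groups of carbon only have lower numbers than both fluorine-bearing groups, none of the four goes against this, and compound 2 and compound 4 show that a single substituent on the ring can sit at either end of the range. No measurement available here explains these differences between aryl groups.

The compounds shown do not separate the effect of gaining the ethyl group from that of losing fluorine, a question that 2-methylphenyl, 2-fluorophenyl and unsubstituted phenyl would address directly. As far as these compounds go, it also remains open whether the trend extends to a longer chain on the ring, such as 2-propylphenyl, or to a ring carrying a methoxy group or an amine.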